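The compounds below may be only part of what the source reports. "The series", "measured", "known", "first", "only" and "open" are said of these compounds alone.

- compound 1 (`CC(=O)NCC(=O)N(C)c1ccc(Cl)cc1C(=O)c1ccccc1Cl`) gives 58 mg/kg
- compound 2 (`CC(NC(=O)CN)C(=O)N(C)c1ccc(Cl)cc1C(=O)c1ccccc1Cl`) gives 8.5 mg/kg

Among the compounds with values here, in a functional assay on the whole organism with Mus musculus as the target, in the rotarod test (a lower number here means that less compound is needed, a higher number that more compound is needed for the effect), compound 1 holds the higher of the two numbers, and compound 2 is its only neighbour (a 6.8-fold lower number from compound 1 to compound 2 (0.83 log units; beyond the scatter)). Compound 3 (`CN(C(=O)CNC(=O)CN1CCN(c2ccccc2)CC1)c1ccc(Cl)cc1C(=O)c1ccccc1Cl`) differs from compound 1 by one change (4-phenylpiperazin-1-yl in place of hydrogen on a saturated chain carbon bound to a carbonyl carbon). Within the data shown here, the single measured step bearing on this is modest and beyond the scatter (a 6.8-fold lower number from compound 1 to compound 2 (0.83 log units; beyond the scatter)). It is a different change, also on a carbonyl carbon, so it is only a loose guide. A smaller step in the same direction is expected in this assay (a 1.7-fold lower number from compound 1 to compound 3 (0.22 log units; within the scatter)). Compound 3 is estimated at 35 mg/kg, with an expected range of 10 mg/kg to 120 mg/kg.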

Compound 3, dose for half-maximal effect: > 100 mg/kg
Compound 3: no number, only a limit; the forecaster's own chance of this, stated with the estimate: 25%; at least 2.8-fold (0.45 log units) between middle value and limit.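

In this assay compound 3 gives only a limit, not a number: the limit of > 100 mg/kg in this assay, at which 1 of the 3 values shown sits. Placing 4-phenylpiperazin-1-yl in place of hydrogen on the saturated chain carbon bound to a carbonyl carbon gives an at least 1.7-fold higher number from compound 1 to compound 3 (0.23 log units; that floor lies within the scatter). This change therefore shows none of the lowering seen in the other change to the series, a 6.8-fold lower number from compound 1 to compound 2 (0.83 log units; beyond the scatter).

Going by these compounds, the true value of compound 3 stays open, and so does the real size of its step. Also open, on these data alone, is whether a simple amine such as dimethylamino on this carbon would give a lower number than compound 1.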